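A few compounds are considered here, and "the series" means these few. Any claim that something is new, unique, unknown or untested is made for them only; others in the source may bear on it.

Measured in a functional assay on A549 cells (Homo sapiens) for inhibition, read by CCK-8 assay, with a stated time of 72 h, tested at 10 uM; a higher number here means more inhibition of growth at the concentration tested, a lower number less inhibition of growth:
- Compound 1 `CN(C)C(=O)c1cc2cnc(Nc3ccc(NC(=O)C4(C(=O)Nc5ccc(Cl)cc5)CC4)cc3)nc2n1C1CCCC1`: 101%
- Compound 2 `CN(C)C(=O)c1cc2cnc(Nc3ccc(NC(=O)C4(C(=O)Nc5ccc(Cl)c(C(F)(F)F)c5)CC4)cc3)nc2n1C1CCCC1`: 88.1%
- Compound 3 `CN(C)C(=O)c1cc2cnc(Nc3ccc(NC(=O)C4(C(=O)Nc5cccc(C#N)c5)CC4)cc3)nc2n1C1CCCC1`: 73.6%

Compound 3 stands lowest of the three, and the other two compounds both lie above it by more than the scatter. Compound 4 `CN(C)C(=O)c1cc2cnc(Nc3ccc(NC(=O)C4(C(=O)Nc5ccc(C#N)cc5)CC4)cc3)nc2n1C1CCCC1` has the same atoms, joined differently, with 4-cyanophenyl in place of 3-cyanophenyl on an amide-type nitrogen. For the measured compounds named here, no measured step makes this change alone, so the evidence is indirect. The closest is the step of a number 27.4 percentage points lower from compound 1 to compound 3 (beyond the scatter), which replaces 4-chlorophenyl with 3-cyanophenyl and so alters the group and its placement together. The step of a number 14.5 percentage points lower from compound 2 to compound 3 (beyond the scatter) also replaces a whole group, while the step of a number 12.9 percentage points lower from compound 1 to compound 2 (beyond the scatter) shows that a single added trifluoromethyl can matter. Compound 4 resembles compound 1, at 101%, in having a 4-substituted phenyl, so a modest rise in this assay is expected. The expected step is a number 7.4 percentage points higher from compound 3 to compound 4 (within the scatter), which may not clear the scatter. For compound 4 the estimate is 81%, with an expected range of 63% to 98%.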

Compound 4, percent growth inhibition at one concentration: 95%
For compound 4 the middle estimate is 14 percentage points below the measured one; low and high end bracket the measured number.
By their numbers in this assay, from the lowest: compound 3; then compounds 2, 4 and 1 (each within the scatter of the next, the first and the last beyond it).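

Compound 3 and compound 4 have the same atoms, joined differently. For the compounds shown here, the step of a number 21.4 percentage points higher from compound 3 to compound 4 (beyond the scatter) in this assay isolates what the earlier steps could not: those swapped the group and its placement together, while here placement alone changes the number, with 4-cyanophenyl in place of 3-cyanophenyl on the amide-type nitrogen. The 4-cyanophenyl group also cannot be told apart from the two other groups, with a number 6 percentage points lower from compound 1 to compound 4 (within the scatter) and a number 6.9 percentage points higher from compound 2 to compound 4 (within the scatter) in the same assay. Nothing shown here explains why the two placements differ.

On these data alone, it remains open whether the nitrile itself matters, which a 4-aminophenyl or 4-carboxyphenyl group on the same amide-type nitrogen could help to settle. The compounds shown also leave open whether moving a chloro group would have a comparable effect.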